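Removing the methoxy group from a cinnamamide urotensin agonist

The compounds below may be only part of what the source reports. "The series", "measured", "known", "first", "only" and "open" are said of these compounds alone.

Measured so far:
Compound 1, `Cc1ccc(C(CCN(C)C)NC(=O)CCc2ccccc2)cc1`, gives 4570 nM.
Compound 2, `COc1ccc(/C=C/C(=O)NC(CCN(C)C)c2ccc3ccccc3c2)cc1`, gives 380 nM.

Both values come from a functional assay on NIH3T3 cells for agonist activity at Urotensin-2 receptor (Homo sapiens), with a stated time of 5 days; a lower number here means that less compound is needed, a higher number that more compound is needed for the effect. Going by the values given here, of the two numbers known, compound 2 holds the lower one; the nearest neighbour is compound 1, whose number, 4570 nM, lies higher by a margin beyond the usual scatter. Among the compounds with values here, the two compounds differ in several places at once, so no single step between them is isolated.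

Compound 3, `CN(C)CCC(NC(=O)/C=C/c1ccccc1)c1ccc2ccccc2c1`, has not yet been measured. It keeps the core of compound 2 and changes one thing: hydrogen in place of methoxy on an aromatic carbon. Within the data shown here, no measured pair shows this change, so its effect in this assay can only be expected, not read off. Taking compound 2 at 380 nM as the anchor, a modest rise in the number, of a size near the edge of the scatter, is expected for compound 3. The step expected is a 2.1-fold higher number from compound 2 to compound 3 (0.32 log units; beyond the scatter). Compound 3 is therefore estimated at 800 nM, with a range from 250 nM to 2500 nM.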

Compound 3, half-maximal effective concentration: 589 nM
Beside the measured number, compound 3's estimate is 1.4-fold (0.13 log units) above it; the measured number falls inside the stated range.
By their numbers in this assay, from the lowest: compounds 2 and 3 (each within the scatter of the next); then compound 1.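

In this assay, replacing the methoxy group with hydrogen on an aromatic carbon, para to a large group, gives a 1.6-fold higher number from compound 2 to compound 3 (0.19 log units; within the scatter), and this is the only pair shown that differs in one place. The result indicates that, with the rest of compound 2 kept, the change from 4-methoxyphenyl to phenyl can be made without a shift beyond the scatter, so this assay does not separate compound 2 from compound 3 and the two heavy atoms and the hydrogen-bond acceptor of the methoxy group are not required to stay in this range of numbers. No measured property of either group bears on this result, so the outcome stands as an observation without an explanation.

On these data alone, whether a fluorine, a hydroxyl, a dimethylamino group or a carboxylic acid at this same place would also leave the number within the scatter of compound 3 remains open, as does whether the outcome would hold on another core. Compound 1 differs from compound 2 and compound 3 in several places at once, so the steps that link it to them cannot be read.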